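A few compounds are considered here, and "the series" means these few. Any claim that something is new, unique, unknown or untested is made for them only; others in the source may bear on it.

Two measured compounds set the scene. Compound 1 `COc1c(N2CC[C@@H](N)C2)c(F)cc2c(=O)c(C(=O)O)cn(Cc3ccc(-c4ccccc4)cc3)c12` and compound 2 `NC[C@@H]1CCN(c2cc3c(cc2F)c(=O)c(C(=O)O)cn3Cc2ccc(-c3ccccc3)cc2)C1` share a core and were both tested in an assay on isolated protein for inhibition of DNA topoisomerase 1 (Homo sapiens), with a stated time of 15 min; on this read-out higher numbers stand for weaker inhibition and lower numbers for stronger inhibition. There compound 1 gives 92200 nM, and compound 2 gives 15600 nM. Of the two numbers, that of compound 1 is the higher one, and the gap to compound 2 lies beyond the scatter of repeated measurements, so compound 1 is the weaker inhibitor of the pair. Among the measured compounds shown here, the two structures differ in more than one place, so no single step between them can be read from these values.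

Compound 3 `COc1c(N2CC[C@@H](CO)C2)c(F)cc2c(=O)c(C(=O)O)cn(Cc3ccc(-c4ccccc4)cc3)c12` has not yet been measured in this assay. It differs from compound 1 in one place: hydroxymethyl in place of amino on a saturated ring carbon. For the measured compounds named here, nothing among the measured compounds isolates this change, and the account therefore rests on the step from compound 1 alone. Compound 3 is expected to stay close to its parent, with the estimated step of a 1.2-fold higher number from compound 1 to compound 3 (0.08 log units; within the scatter) lying within the scatter or only slightly toward weaker inhibition. For compound 3 the estimate in this assay is 110000 nM, with a range from 35000 nM to 350000 nM.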

Compound 3, half-maximal inhibitory concentration: > 200000 nM
Compound 3: only a limit was reported; the forecaster's own chance of this, stated with the estimate: 30%; middle value at least 1.8-fold (0.25 log units) from the limit.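

In this assay compound 3 gives > 200000 nM as a limit of the assay and not as a number. Among the compounds shown here, the change from 3-aminopyrrolidin-1-yl to 3-(hydroxymethyl)pyrrolidin-1-yl gives an at least 2.1-fold higher number from compound 1 to compound 3 (0.33 log units; beyond the scatter) on this read-out, which makes it the first step at this position that can be read in one place, and it shows that inhibition, already weak in compound 1, does not hold when hydroxymethyl replaces amino on this saturated ring carbon, even though both groups carry the same counts of hydrogen-bond donors and acceptors and no net charge. The size of this step is only a bound, and it rests on a single reading: the limit of > 200000 nM in this assay, at which 1 of the 3 values shown sits.

From the compounds shown here alone, how far compound 3 actually lies from compound 1 stays open, and so does whether the loss follows from the missing nitrogen or from the extra carbon that comes with hydroxymethyl. The compounds shown also leave open what a plain hydroxyl, a dimethylamino group or a carboxylic acid on the same ring carbon would do on the core of compound 1.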